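The source may hold more compounds than are shown below. What is called first, only, known or untested is meant among the compounds shown, and "the series" means these compounds.

Measured compounds:
compound 1 `CCOc1cc(NC(=O)CCCCCCC(=O)Nc2ccccc2N)cc2c1OCC([N+](=O)[O-])=C2`, 3360 nM in a functional assay on K562 cells (Homo sapiens) for antiproliferative activity, read by MTT assay, with a stated time of 48 h; on this read-out lower numbers stand for stronger inhibition of growth and higher numbers for weaker inhibition of growth
compound 2 `CCOc1cc(NC(=O)CCCCCCC(=O)Nc2cc(-c3ccc(C)s3)ccc2N)cc2c1OCC([N+](=O)[O-])=C2`, 3110 nM in this assay
compound 3 `CCOc1cc(NC(=O)CCCCC(=O)Nc2cc(-c3ccc(C)s3)ccc2N)cc2c1OCC([N+](=O)[O-])=C2`, 2940 nM in this assay

Compound 1 and compound 2 differ by one change, (hydrogen in place of 5-methylthiophen-2-yl on an aromatic carbon), and the measured step is a 1.1-fold higher number from compound 2 to compound 1 (0.03 log units; within the scatter). Compound 3 carries a different core from compound 2; the difference between the two cores is not broken down here. Compound 4 `CCOc1cc(NC(=O)CCCCC(=O)Nc2ccccc2N)cc2c1OCC([N+](=O)[O-])=C2` is not yet measured. It stands to compound 3 as compound 1 stands to compound 2: the change is hydrogen in place of 5-methylthiophen-2-yl on an aromatic carbon, the same change at the same place.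

The step from compound 3 to compound 4 in this assay is expected to be small, a 1.1-fold higher number from compound 3 to compound 4 (0.04 log units; within the scatter), because the same change measured as a 1.1-fold higher number from compound 2 to compound 1 (0.03 log units; within the scatter). For compound 4 the expected value in this assay is 3200 nM.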

Compound 4, concentration for 50% growth inhibition: 3680 nM
Compound 4: the middle estimate sits 1.2-fold (0.06 log units) below what was measured; low and high end bracket the measured number.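

In this assay, hydrogen in place of 5-methylthiophen-2-yl on the core of compound 3 gives a 1.3-fold higher number from compound 3 to compound 4 (0.10 log units; within the scatter). The two steps for this change do not differ on these two cores: the same change on two cores in this assay, a 1.1-fold higher number (0.03 log units; within the scatter) from compound 2 to compound 1 and a 1.3-fold higher number (0.10 log units; within the scatter) from compound 3 to compound 4, 1.2-fold (0.06 log units) apart, within the scatter of two such steps This shows that the change carries over between these two cores with no readable effect on this read-out, but it does not show that the step would stay this small on any other core or in any other assay.

Still open, from the compounds shown here alone, is whether another group at the same place, such as a phenyl ring or a fluorine atom, would give a step beyond the scatter. Within the data shown here, also open is what a chain longer than the one in compound 2 would do, with or without the 5-methylthiophen-2-yl group.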